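Cytotoxicity notes on a benzyl-substituted nucleoside series

The compounds below may be only part of what the source reports. "The series", "measured", "known", "first", "only" and "open" are said of these compounds alone.

Measured so far, in an ADME assay on NIH3T3 cells (Mus musculus) for cytotoxicity, with a stated time of 72 h; on this read-out lower numbers stand for stronger inhibition and higher numbers for weaker inhibition:
- compound 1 `Cc1cccc(CNc2ncnc3c2ncn3[C@@H]2O[C@H](CO)[C@@H](O)[C@H]2O)c1`: > 166000 nM
- compound 2 `OC[C@H]1O[C@@H](n2cnc3c(NCc4c(F)ccc(F)c4F)ncnc32)[C@H](O)[C@@H]1O`: "not determined" (no result reported)

Compound 1 stands at the limit of > 166000 nM in this assay, at which 1 of the 2 values shown sits, which is a limit of this assay and not a number. For compound 2 no result was reported in this assay, so the series carries no single measured number at all. Going by the values given here, no step between two measured compounds is available, and nothing shows how this assay responds to a change at the benzyl group.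

Compound 3 `OC[C@H]1O[C@@H](n2cnc3c(NCc4ccc(F)c(Cl)c4)ncnc32)[C@H](O)[C@@H]1O` is the next entry. It differs from compound 1 in one place: 3-chloro-4-fluorophenyl in place of 3-methylphenyl on a saturated chain carbon bound to a nitrogen on an aromatic ring. The place itself is unchanged, so the core of compound 1 and its sugar are kept as they stand.

With compound 1 giving only a limit, the step from compound 1 to compound 3 is expected to be small or none beyond the scatter, in the sense of staying at weak inhibition; the expected step reads an at least 1.1-fold lower number from compound 1 to compound 3 (0.04 log units; that floor lies within the scatter). For compound 3 the estimate in this assay is 150000 nM, within 50000 nM to 300000 nM, and it is expected that a limit rather than a number is again the likely outcome.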

Compound 3, half-maximal inhibitory concentration: > 166000 nM
Compound 3 ended at the assay's limit; the forecaster's own chance of this, stated with the estimate: 75%; middle value at least 1.1-fold (0.04 log units) from the limit.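

Compound 1 and compound 3 each carry a limit and not a number in this assay, so no step between them can be read: the limit of > 166000 nM in this assay, at which 2 of the 3 values shown sit.

The compounds shown leave open how 3-chloro-4-fluorobenzyl and 3-methylbenzyl compare in this assay, and whether any change at this place gives a single number.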